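Biaryl imidazolyl carbinols: a pyridin-2-yl replacement

This account rests on a few compounds, and the source may have more. Where it says the series, first, only, none or still open, it means among the compounds named here.

Measured compounds:
compound 1 `COc1ccc(-c2ccc(C(O)(c3c[nH]cn3)C(C)C)cc2)cc1`, 120 nM
compound 2 `CC(C)C(O)(c1ccc(-c2ccc(Cl)cc2)cc1)c1c[nH]cn1`, 29 nM
compound 3 `CC(=O)Nc1ccc(-c2ccc(C(O)(c3c[nH]cn3)C(C)C)cc2)cc1`, 24 nM

In an assay on microsomes from Testis (strain Sprague-Dawley) for inhibition of steroid 17-alpha-hydroxylase/17,20 lyase (Rattus norvegicus) (on this read-out higher numbers stand for weaker inhibition and lower numbers for stronger inhibition), compound 2 gives 29 nM, the second highest of the three numbers. Compound 3 gives 24 nM, with a 1.2-fold lower number from compound 2 to compound 3 (0.08 log units; within the scatter). Compound 1 gives 120 nM, with a 4.1-fold lower number from compound 1 to compound 2 (0.62 log units; beyond the scatter) and a 5.0-fold lower number from compound 1 to compound 3 (0.70 log units; beyond the scatter). Compound 4 `CC(C)C(O)(c1ccc(-c2ccccn2)cc1)c1c[nH]cn1` is not yet measured; its change from compound 2 is pyridin-2-yl in place of 4-chlorophenyl on an aromatic carbon. For the measured compounds named here, none of the measured steps bears directly on this: each of them varies only a single group on the 4-chlorophenyl that now leaves, and all of those steps were modest. Going by the values given here, removing the whole ring, chloro included, has no precedent in this set, so the expectation is uncertain. Compound 4 is expected to give 80 nM, between 30 nM and 250 nM, an expected step of a 2.8-fold higher number from compound 2 to compound 4 (0.44 log units; beyond the scatter).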

Compound 4, half-maximal inhibitory concentration: 210 nM
For compound 4 the middle estimate is 2.6-fold (0.42 log units) below the measured one; low and high end bracket the measured number.
By their numbers in this assay, from the lowest: compounds 3 and 2 (each within the scatter of the next); then compounds 1 and 4 (each within the scatter of the next).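

In this assay, pyridin-2-yl in place of 4-chlorophenyl gives a 7.2-fold higher number from compound 2 to compound 4 (0.86 log units; beyond the scatter), the largest step yet seen at this position. Against 4-methoxyphenyl the same ring gives a 1.8-fold higher number from compound 1 to compound 4 (0.24 log units; within the scatter), so the outcome of exchanging the whole ring depends on which substituted phenyl leaves, and the position responds to more than the single group varied earlier. Nothing available explains this difference. The compounds shown leave open whether the ring nitrogen or the lost substituent accounts for the step. An unsubstituted phenyl or a chloropyridinyl ring would separate the two.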